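Closing an Open Amide into a Lactam Ring

A few compounds are considered here, and "the series" means these few. Any claim that something is new, unique, unknown or untested is made for them only; others in the source may bear on it.

Measured compounds in an assay on CHO cells for agonist activity at Glucose-dependent insulinotropic receptor (Homo sapiens), read by a luciferase reporter and cAMP accumulation, with a stated time of 2 h; on this read-out higher numbers stand for an effect only at larger amounts of compound and lower numbers for an effect already at smaller amounts:
compound 1 `CC(C)c1noc(N2CCC(Oc3cc(N4CCc5cc(N6CCCCC6=O)ccc54)ncn3)CC2)n1` gives 17 nM
compound 2 `CC(C)SC(=O)N1CCC(Oc2cc(N3CCc4cc([S+]([O-])CCO)ccc43)ncn2)CC1` gives 14 nM; 57 nM; 9.7 nM (3 entries)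
compound 3 `CC(=O)N(C)c1ccc2c(c1)CCN2c1cc(OC2CCN(c3nc(C(C)C)no3)CC2)ncn1` gives 75 nM

Compound 3 has the highest of the two single numbers in this assay; its nearest neighbour is compound 1, whose number is lower, and the gap between them is beyond the scatter. Compound 2 has several entries rather than one number, and the several entries of compound 2 in this assay, 14 nM; 57 nM; 9.7 nM (3 entries) shows how widely repeat measurements of one compound can spread.

The unmeasured compound 4 `CC(C)c1noc(N2CCC(Oc3cc(N4CCc5cc(N6CCOCC6=O)ccc54)ncn3)CC2)n1` differs from compound 3 only at one spot on the fused ring system: 3-oxomorpholin-4-yl in place of acetyl(methyl)amino on an aromatic carbon. For the measured compounds named here, this is close to the reverse of the one measured step, a 4.4-fold higher number from compound 1 to compound 3 (0.64 log units; beyond the scatter), where an open acetyl(methyl)amino group replaced a ring-closed 2-oxopiperidin-1-yl and the number rose. The 3-oxomorpholin-4-yl group of compound 4 is likewise a six-membered ring-closed amide, differing from 2-oxopiperidin-1-yl only by one extra ring oxygen. The step of a 3.4-fold lower number from compound 3 to compound 4 (0.53 log units; beyond the scatter) is therefore expected to run downward, roughly undoing the rise seen from compound 1 to compound 3.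

Compound 4 is expected to give about 22 nM in this assay, within a range from 9 nM to 60 nM.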

Compound 4, half-maximal effective concentration: 15 nM
The estimate for compound 4 lay 1.5-fold (0.17 log units) above the measured number; measured number inside the range.
By their numbers in this assay, from the lowest: compounds 4 and 1 (each within the scatter of the next); then compound 3.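

In this assay, replacing the open acetyl(methyl)amino group with the ring-closed 3-oxomorpholin-4-yl group gives a 5.0-fold lower number from compound 3 to compound 4 (0.70 log units; beyond the scatter). This shows that the earlier gap, a 4.4-fold higher number from compound 1 to compound 3 (0.64 log units; beyond the scatter), was not special to 2-oxopiperidin-1-yl: among these three compounds, both six-membered ring-closed amides read lower than the open amide. The extra ring oxygen makes no difference that can be read, since swapping one ring for the other gives a 1.1-fold lower number from compound 1 to compound 4 (0.05 log units; within the scatter), and so this position accepts either ring, with any small gap between them needing caution given how far repeat measurements can spread, as seen in: the several entries of compound 2 in this assay, 14 nM; 57 nM; 9.7 nM (3 entries)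

Going from the open group to the ring also adds heavy atoms and a second hydrogen-bond acceptor, so the compounds shown cannot separate the effect of the ring itself from that of these other changes. They also leave open how a five-membered 2-oxopyrrolidin-1-yl ring, or a plain dimethylamino group with no carbonyl, would read on this aromatic carbon.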